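The source may report more compounds than this note shows. Statements on the series, on what has been measured and on what is new or still open speak of the compounds shown alone.

Working notes on the amide side chain, read in a functional assay on MCF7 cells (Homo sapiens) for antiproliferative activity, read by CCK-8 assay, with a stated time of 72 h; on this read-out higher numbers stand for weaker inhibition of growth and lower numbers for stronger inhibition of growth. Within the data shown here, compound 1 (`CCCNC(=O)c1ccc2c(ccn2-c2ncc3c(n2)N(c2ccn(C)n2)C(CC)C(=O)N3C)c1`) gives 6420 nM, and compound 2 (`CCNC(=O)c1ccc2c(ccn2-c2ncc3c(n2)N(c2ccn(C)n2)C(CC)C(=O)N3C)c1`) gives 13200 nM, the higher of the two numbers so far. Among the measured compounds shown here, compound 1 is therefore the only neighbour of compound 2, on the stronger side. Next comes compound 3 (`CCC1C(=O)N(C)c2cnc(-n3ccc4cc(C(=O)NCC(C)C)ccc43)nc2N1c1ccn(C)n1`), which differs from compound 2 by isopropyl in place of methyl on a saturated chain carbon bound to an amide-type nitrogen. Read one bond further out, this is ethylcarbamoyl changing to isobutylcarbamoyl.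

For the measured compounds named here, only one measured step bears on this change: a 2.1-fold higher number from compound 1 to compound 2 (0.31 log units; beyond the scatter). It is modest and lies just beyond the scatter. Going from compound 2 back to compound 1, the longer chain gives the lower number. Going by the values given here, this is a single pair, and no branched chain has yet been measured, so the direction is only a tentative guide. A modest move toward stronger inhibition of growth is expected, with the estimated step being a 2.6-fold lower number from compound 2 to compound 3 (0.42 log units; beyond the scatter). For compound 3 the estimate is 5000 nM, with an expected range of 2200 nM to 11500 nM.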

Compound 3, concentration for 50% growth inhibition: 4810 nM
The estimate for compound 3 lay 1.0-fold (0.02 log units) above the measured number; low and high end bracket the measured number.
By their numbers in this assay, from the lowest: compounds 3 and 1 (each within the scatter of the next); then compound 2.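

In this assay, the change from ethylcarbamoyl to isobutylcarbamoyl gives a 2.7-fold lower number from compound 2 to compound 3 (0.44 log units; beyond the scatter) and so extends the reading at this amide side chain to a branched chain, which until now rested on the straight propyl chain of compound 1 alone. The comparison of the branched and straight chains gives a 1.3-fold lower number from compound 1 to compound 3 (0.13 log units; within the scatter) for methyl in place of hydrogen on a saturated chain carbon bound to two saturated chain carbons, so this added methyl brings no readable change in this assay. Among these three compounds, compound 1 and compound 3 both stand on the stronger side of compound 2, none goes against that pattern, and compound 1 and compound 3 cannot be ordered.

Still open, from the compounds shown here alone, is whether the pattern holds for a longer chain such as pentyl, or for a cyclopropylmethyl group, and whether it survives once the chain carries an amine or a carboxylic acid. The same side chains on any other cell line also remain an open question. Nothing available here gives a reason for either step.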